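Hydroxy versus methyl cores: fluoro para step

The source may hold more compounds than are shown below. What is called first, only, known or untested is meant among the compounds shown, and "the series" means these compounds.

Measured compounds:
compound 1 `Oc1cccc2[nH]c(-c3ccc(-c4ccc(-c5ccccc5)cc4)cc3)nc12` gives 35600 nM in a functional assay on ZR-75-1 cells (Homo sapiens) for inhibition, read by sulforhodamine B assay; on this read-out lower numbers stand for stronger inhibition of growth and higher numbers for weaker inhibition of growth
compound 2 `Oc1cccc2[nH]c(-c3ccc(-c4ccc(-c5ccc(F)cc5)cc4)cc3)nc12` gives 6320 nM in this assay
compound 3 `Cc1ccc2[nH]c(-c3ccc(-c4ccc(-c5ccccc5)cc4)cc3)nc2c1` gives 27400 nM in this assay

Compound 1 and compound 3 carry different cores; the difference between the two cores is not broken down here. Their numbers lie close together, and compound 3 in this assay is within the scatter of compound 1.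

Compound 4 `Cc1ccc2[nH]c(-c3ccc(-c4ccc(-c5ccc(F)cc5)cc4)cc3)nc2c1` is not yet measured. It stands to compound 3 as compound 2 stands to compound 1. The change made from compound 1 to compound 2 is

fluoro in place of hydrogen on an aromatic carbon

and the change from compound 3 to compound 4 is

fluoro in place of hydrogen on an aromatic carbon

The two place descriptions are the same word for word, so this is the same change on a different core. In this assay it made the step of a 5.6-fold lower number from compound 1 to compound 2 (0.75 log units; beyond the scatter).

Within the data shown here, for compound 4 the expected step is a 5.0-fold lower number from compound 3 to compound 4 (0.70 log units; beyond the scatter), resting on the one measured example of this change in compound 1 to compound 2 a 5.6-fold lower number from compound 1 to compound 2 (0.75 log units; beyond the scatter) and on the value of compound 3 27400 nM. Among the measured compounds shown here, with only one prior example the size carries uncertainty. The estimate for compound 4 in this assay is 5500 nM, expected to fall between 2500 nM and 14000 nM.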

Compound 4, concentration for 50% growth inhibition: 35000 nM
The estimate for compound 4 lay 6.4-fold (0.80 log units) below the measured number, and the stated range ends below it.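

Phenyl to 4-fluorophenyl does not transfer between the two cores in this assay. Among these compounds, on the second core the step is a 1.3-fold higher number from compound 3 to compound 4 (0.11 log units; within the scatter), so the clear change seen on the first core has no counterpart here. Set side by side, the two steps differ: the same change on two cores in this assay, a 5.6-fold lower number (0.75 log units; beyond the scatter) from compound 1 to compound 2 and a 1.3-fold higher number (0.11 log units; within the scatter) from compound 3 to compound 4, 7.2-fold (0.86 log units) apart, beyond the scatter of two such steps.

Among these four compounds, the outcome of this fluoro change therefore depends on the core, and a result on one core cannot be used as an estimate for the other. With a single pair on each core, this does not show which part of the core difference matters, or which of the two steps would be the more typical for the series.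

Open, from the compounds shown here alone, is whether other groups in the same place, such as chloro, methoxy or an amine, would also split between the two cores. Also open, going by these compounds, is how the step would behave on a core carrying a methoxy group or a carboxylic acid in place of the hydroxy group.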